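Butyl for propenyl on the sulfur of a benzamide triazole

The source may hold more compounds than are shown below. What is called first, only, known or untested is meant among the compounds shown, and "the series" means these compounds.

Compound 3 `C/C=C/Sc1nnc(COc2ccccc2C2=NOC(c3ccc(Cl)cc3Cl)C2)n1NC(=O)c1ccccc1` has no result in an ADME assay (MDM cells, Homo sapiens) for cytotoxicity, read by resazurin assay, with a stated time of 3 days; a lower number here means a stronger inhibitor, a higher number a weaker inhibitor: for compound 3 the entry reads "not determined" (no result reported), so it stands on no number. Its neighbours do. Compound 1 `CCCSc1nnc(COc2ccccc2C2=NOC(c3ccc(Cl)cc3Cl)C2)n1NC(=O)c1ccccc1`, which carries a propyl chain on the sulfur, gives 14.8 ug/mL in this assay. Compound 2 `CCCCSc1nnc(COc2ccccc2C2=NOC(c3ccc(Cl)cc3Cl)C2)n1NC(C)=O`, with a butyl chain on the sulfur and an acetyl group on the nitrogen, gives 2.6 ug/mL. As far as these compounds go, compound 4 `CCCCSc1nnc(COc2ccccc2C2=NOC(c3ccc(Cl)cc3Cl)C2)n1NC(=O)c1ccccc1` is untested; it differs from compound 3 by butyl in place of prop-1-en-1-yl on a sulfur. Among the compounds with values here, with no number for compound 3 and no measured pair showing this very change, no step size or direction in this assay can be stated, only that compounds 1 and 2 bracket the likely outcome. Compound 4 is expected to give about 7 ug/mL, within 2.5 ug/mL to 22 ug/mL.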

Compound 4, half-maximal inhibitory concentration: 2.5 ug/mL
Beside the measured number, compound 4's estimate is 2.8-fold (0.45 log units) above it; the measured number falls inside the stated range.
By their numbers in this assay, from the lowest: compounds 4 and 2 (each within the scatter of the next); then compound 1.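

In this assay butyl in place of propyl on the sulfur gives a 5.9-fold lower number from compound 1 to compound 4 (0.77 log units; beyond the scatter) with the rest of the molecule unchanged. Phenyl in place of methyl on the carbonyl carbon gives a 1.0-fold lower number from compound 2 to compound 4 (0.02 log units; within the scatter) and so separates the two compounds by no more than the scatter. As far as these compounds go, the step from compound 3 to compound 4 cannot be read, as compound 3 has no number, so the effect of replacing prop-1-en-1-yl with butyl remains unknown. From the compounds shown here alone, whether a longer chain such as hexyl, or an amine at its end, would continue this trend stays open. Nothing measured here accounts for these steps.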